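The source may hold more compounds than are shown below. What is called first, only, known or untested is meant among the compounds shown, and "the series" means these compounds.

Measured compounds:

Compound 1, `Nc1ccccc1NC(=O)/C=C/c1ccc(CNc2ccccc2)cc1`, gives 11000 nM in a functional assay on HCT-116 cells (Homo sapiens) for antiproliferative activity, read by MTT assay; on this read-out lower numbers stand for stronger inhibition and higher numbers for weaker inhibition.
Compound 2, `COc1cccc(NCc2ccc(/C=C/C(=O)Nc3ccccc3N)cc2)c1`, gives 10000 nM in this assay.
Compound 3, `COc1ccc(CNc2ccc(C(=O)Nc3ccccc3N)cc2)cc1OC`, gives 600 nM in this assay.

Compound 2 differs from compound 1 by a single change, (methoxy in place of hydrogen on an aromatic carbon), and the step it made in this assay was a 1.1-fold lower number from compound 1 to compound 2 (0.04 log units; within the scatter). Compound 3 has a different core; how its core differs from that of compound 1 is not broken down here, and its value stands well apart from the other two, as the numbers above show.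

Compound 4, `COc1cc(CNc2ccc(C(=O)Nc3ccccc3N)cc2)cc(OC)c1OC`, is not yet measured. It differs from compound 3 by methoxy in place of hydrogen on an aromatic carbon. This is the same kind of change that took compound 1 to compound 2, but not the same: in compound 3 the place is ortho to a methoxy group and meta to a methoxy group as well as meta to a large group, whereas in compound 1 the place is only meta to a large group. Among the measured compounds shown here, the one measured example of this kind of change, with its step within the scatter, is the only guide available. On that basis compound 4 is expected to stay near compound 3, and the expected step is a 1.2-fold higher number from compound 3 to compound 4 (0.07 log units; within the scatter), resting on the step of a 1.1-fold lower number from compound 1 to compound 2 (0.04 log units; within the scatter). Compound 4 is therefore estimated to give about 700 nM in this assay, with a plausible range from 250 nM to 2000 nM.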

Compound 4, half-maximal inhibitory concentration: 2000 nM
Beside the measured number, compound 4's estimate is 2.9-fold (0.46 log units) below it; low and high end bracket the measured number.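

On the core of compound 3, methoxy in place of hydrogen on an aromatic carbon brought a 3.3-fold higher number from compound 3 to compound 4 (0.52 log units; beyond the scatter), a modest loss of antiproliferative activity. The size of this step therefore does not carry over from the other core in this assay: the same change on two cores in this assay, a 1.1-fold lower number (0.04 log units; within the scatter) from compound 1 to compound 2 and a 3.3-fold higher number (0.52 log units; beyond the scatter) from compound 3 to compound 4, 3.7-fold (0.56 log units) apart, beyond the scatter of two such steps. Among the compounds shown here, this shows that a step measured on one core is a poor guide to the same change on the other core, but it rests on only two pairs and does not show why they differ, since the cores are not the only difference: in compound 4 the new methoxy is ortho to a methoxy group and meta to a methoxy group, which the core of compound 1 does not offer, so the effect of the core cannot be separated from that of these surroundings.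

The compounds shown leave open whether a hydroxyl group, an ethoxy group or a fluorine atom at this place on the core of compound 3 would give a similar step. They also leave open how the core of compound 1 would respond to a new methoxy group if methoxy groups were already present on that ring.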